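The source may hold more compounds than are shown below. What is called first, only, known or untested is meant among the compounds shown, and "the series" means these compounds.

Measured so far in a functional assay on KB cells (Homo sapiens) for inhibition, read by sulforhodamine B assay; a higher number here means a weaker inhibitor of growth, a lower number a stronger inhibitor of growth
compound 1 `FC(F)(F)Oc1ccc(-c2ccc(-c3ccc(-c4nc5ccccc5[nH]4)cc3)cc2)cc1`: 39100 nM
compound 2 `Oc1cccc2[nH]c(-c3ccc(-c4ccc(-c5ccc(C(F)(F)F)cc5)cc4)cc3)nc12`: 4320 nM

Compound 2 holds the lower number of the pair, and its gap to compound 1 lies beyond the scatter. These two differ in more than one place, so that gap does not isolate any single group. The next analogue, compound 3 `Oc1cccc2[nH]c(-c3ccc(-c4ccc(-c5ccc(OC(F)(F)F)cc5)cc4)cc3)nc12`, carries trifluoromethoxy in place of trifluoromethyl on an aromatic carbon, para to a large group (trifluoromethoxy in place of trifluoromethyl on an aromatic carbon), with the rest of compound 2 unchanged. Among the compounds with values here, no measured pair shows this exchange alone, so the expectation in this assay rests only on the structural change: no shift beyond the scatter. The estimated step, a 1.2-fold higher number from compound 2 to compound 3 (0.06 log units; within the scatter), is expected to stay within the scatter. For compound 3 the expected value is 5000 nM, with an estimated range from 2000 nM to 13000 nM.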

Compound 3, concentration for 50% growth inhibition: 3310 nM
Compound 3: the middle estimate sits 1.5-fold (0.18 log units) above what was measured; low and high end bracket the measured number.
By their numbers in this assay, from the lowest: compounds 3 and 2 (each within the scatter of the next); then compound 1.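

In this assay, trifluoromethoxy in place of trifluoromethyl on an aromatic carbon, para to a large group, gives a 1.3-fold lower number from compound 2 to compound 3 (0.12 log units; within the scatter), so this position accepts the exchange without a change that can be read. Hydroxy in place of hydrogen on an aromatic carbon now stands alone as a single change, with a 12-fold lower number from compound 1 to compound 3 (1.07 log units; beyond the scatter), which gives the series its first isolated step beyond the scatter, though it rests on this one pair. No measured evidence explains either step.

The compounds shown leave open whether methoxy or an amine in place of hydroxy would retain this large step. They also leave open whether a carboxylic acid or a longer chain in place of trifluoromethoxy would stay within the scatter.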